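This account rests on a few compounds, and the source may have more. Where it says the series, first, only, none or still open, it means among the compounds named here.

Compound 1 `Cc1cc(NC(=O)Cn2nnc(-c3ccccc3)n2)n(C2CCOCC2)n1` gives 115% in an assay on HEK293 cells for activation of Kir3.1/Kir3.2 (Homo sapiens), read by thallium flux; a higher number here means a larger maximal response, a lower number a smaller maximal response. Compound 2 `Cc1cc(NC(=O)Cn2nnc(-c3ccccc3)n2)n(C2CCS(=O)(=O)CC2)n1` reaches only a limit of > 25% in this assay, not a number. The step that the limit leaves unreadable from compound 1 to compound 2 therefore cannot be sized (the limit of > 25% in this assay, at which 1 of the 3 values shown sits). Compound 3 `Cc1cc(NC(=O)Cn2nnc(-c3cc(Cl)cc(Cl)c3)n2)n(C2CCCCC2)n1` gives 82% in this assay, the lower of the two numbers shown, with compound 1 standing higher by more than the scatter. Compound 4 `Cc1cc(NC(=O)Cn2nnc(-c3ccc(C(F)(F)F)cc3)n2)n(C2CCCCC2)n1` differs from compound 3 in one place: 4-(trifluoromethyl)phenyl in place of 3,5-dichlorophenyl on an aromatic carbon. Within the data shown here, none of the measured steps involves a change of this kind, so they give no direction for it. Compound 4 is therefore expected to stay close to its neighbour, with an expected step of a number 2 percentage points lower from compound 3 to compound 4 (within the scatter). The estimate for compound 4 is 80%, with a range from 50% to 110%.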

Compound 4, largest response reached (Emax), in percent of the reference or control that the assay uses: 94%
Estimate against measurement, compound 4: 14 percentage points below; low and high end bracket the measured number.
By their numbers in this assay, from the lowest: compound 3; then compound 4; then compound 1.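

In this assay, among these compounds, 4-(trifluoromethyl)phenyl in place of 3,5-dichlorophenyl gives a number 12 percentage points higher from compound 3 to compound 4 (beyond the scatter), the first readable step at this aromatic carbon. The group here can therefore shift the maximal response by more than the scatter while the rest of the molecule stays fixed. Nothing measured here gives a reason for this step. Still open, as far as these compounds go, is whether the step carries over to a compound with oxan-4-yl on the aromatic nitrogen. From the compounds shown here alone, how an amine or a carboxylic acid on the phenyl ring would behave is also open.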